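Chloro added to the benzofuran ring: compound 2 to compound 3

The source may report more compounds than this note shows. Statements on the series, on what has been measured and on what is new or still open speak of the compounds shown alone.

Measured so far:
compound 1, `CC(C)(C)c1cc(C(C)(C)C)c2oc(C(c3ccc(Cl)cc3)c3c[nH]c4ccccc34)cc2c1`, 49800 nM in this assay
compound 2, `Cc1c(C(c2ccccc2)c2cc3ccccc3o2)[nH]c2ccccc12`, > 100000 nM in this assay

Two compounds carry a value in a functional assay on SiHa cells (Homo sapiens) for cytotoxicity; on this read-out higher numbers stand for weaker inhibition and lower numbers for stronger inhibition. Compound 1 `CC(C)(C)c1cc(C(C)(C)C)c2oc(C(c3ccc(Cl)cc3)c3c[nH]c4ccccc34)cc2c1` gives 49800 nM. For compound 2 `Cc1c(C(c2ccccc2)c2cc3ccccc3o2)[nH]c2ccccc12` the assay reports only a limit, > 100000 nM, so there is no number to place it with; the run stops at the limit of > 100000 nM in this assay, at which 1 of the 2 values shown sits. Going by the values given here, compound 2 therefore stands at the edge of what the assay can report, and compound 1 is the only compound with a measured point.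

Compound 3 `Cc1c(C(c2ccccc2)c2cc3cc(Cl)ccc3o2)[nH]c2ccccc12` is compound 2 with one change: chloro in place of hydrogen on an aromatic carbon. Among the compounds with values here, no step between two measured compounds shares this change, so the size of the step is open. With compound 2 sitting at a limit, the expectation is that compound 3 remains weak and that any step an at least 1.2-fold lower number from compound 2 to compound 3 (0.09 log units; that floor lies within the scatter) would not go beyond the scatter. Compound 3 is estimated at 80000 nM, with a range from 30000 nM to 200000 nM.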

Compound 3, half-maximal inhibitory concentration: 77900 nM
Beside the measured number, compound 3's estimate is 1.0-fold (0.01 log units) above it; the range from low to high includes it.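

Chloro in place of hydrogen on an aromatic carbon, at the position meta to a fused ring and para to a fused ring, gives the series a measured value at this position: in this assay, compound 3 gives 77900 nM.

Compound 2 carries only a limit of the assay, > 100000 nM.

The change therefore reads as an at least 1.2-fold lower number from compound 2 to compound 3 (0.10 log units; that floor lies within the scatter), which fixes only a floor that lies within the scatter, so the data show neither a real gain from chloro nor its absence, and the true size of the step stays undetermined: the limit of > 100000 nM in this assay, at which 1 of the 3 values shown sits.

Open, from the compounds shown here alone, is whether an amine, a carboxylic acid or a methoxy group on this same aromatic carbon would give a number that separates from compound 3 by more than the scatter in this assay. Also open, going by these compounds, is whether chloro on another carbon of this ring, or the same change on the core of compound 1, would give a step of similar size, since this single step supports no pattern beyond compound 2 and compound 3.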